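From Thiophen-3-yl to 4-(Methoxycarbonyl)phenyl on the Shared Core

The source may report more compounds than this note shows. Statements on the series, on what has been measured and on what is new or still open speak of the compounds shown alone.

Compound 1 `Cc1ccccc1-n1nc(C)c2c1NC(=O)[C@H](C)S[C@@H]2c1ccc(-c2ccsc2)cc1` is one of three measured compounds built on the same core, each carrying a different aromatic group on the outer phenyl ring. In an assay on isolated protein for agonist activity at Bile acid receptor (Homo sapiens), read by AlphaScreen, with a stated time of 30 min (a lower number here means that less compound is needed, a higher number that more compound is needed for the effect), compound 1 gives 1400 nM. This is the lowest of the three numbers, but only narrowly, and the other two sit within the usual scatter of it, so no order among the three can be claimed. Compound 2 `Cc1nn(-c2ccccc2C(C)C)c2c1[C@@H](c1ccc(Oc3ccccc3)cc1)S[C@@H](C)C(=O)N2` gives 1900 nM in this assay. Compound 3 `COc1cc([C@H]2S[C@@H](C)C(=O)Nc3c2c(C)nn3-c2ccccc2C)ccc1Oc1ccccc1` gives 1900 nM in this assay.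

Compound 4 `COC(=O)c1ccc(-c2ccc([C@H]3S[C@@H](C)C(=O)Nc4c3c(C)nn4-c3ccccc3C)cc2)cc1` has not yet been measured. It differs from compound 1 in one place: 4-(methoxycarbonyl)phenyl in place of thiophen-3-yl on an aromatic carbon. Among the compounds with values here, no pair of measured compounds shows what such an exchange does, since the three measured compounds differ from one another in more than one place. With the three measured numbers so close together despite different outer groups, the step from compound 1 to compound 4 is expected to be small, a 1.1-fold higher number from compound 1 to compound 4 (0.03 log units; within the scatter), not beyond the scatter in either direction. Compound 4 is therefore estimated to give 1500 nM in this assay, most likely between 500 nM and 4500 nM.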

Compound 4, half-maximal effective concentration: "not active" (no number reported)
The entry for compound 4 holds no number; there is nothing to compare the estimate with.
By their numbers in this assay, from the lowest: compounds 1, 2 and 3 (each within the scatter of the next).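

Within the data shown here, compound 4 is recorded as "not active", without a number, and no step from compound 1 to compound 4 can be read. Nothing shown here accounts for that entry. The compounds shown leave open how far exchanging thiophen-3-yl for 4-(methoxycarbonyl)phenyl moves the number in this assay.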